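A few compounds are considered here, and "the series" means these few. Any claim that something is new, unique, unknown or untested is made for them only; others in the source may bear on it.

In a functional assay on HOS-TE85 cells (Homo sapiens) for inhibition, read by CCK-8 assay, with a stated time of 72 h (on this read-out lower numbers stand for stronger inhibition and higher numbers for weaker inhibition), compound 3 `CC(F)(F)c1cccc(N2C(=O)CSC2c2cccc(C(=O)NCCCCc3ccccc3)c2)c1` gives 29.1 nM. Of the two plain numbers recorded, this is the lowest; the nearest is compound 1 `O=C(NCCCCc1ccccc1)c1cccc(C2SCC(=O)N2c2cccc(-c3c[nH]nn3)c2)c1`, which gives 110 nM in this assay, the two being separated by the step of a 3.8-fold lower number from compound 1 to compound 3 (0.58 log units; beyond the scatter). Compound 2 `O=C(NCCCCc1ccccc1)c1cccc(C2SCC(=O)N2c2ccc(-c3ccccc3)cc2)c1` is reported only as a limit of the assay, > 1000 nM, and not as a number (the limit of > 1000 nM in this assay, at which 1 of the 3 values shown sits).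

Compound 4 `O=C(NCCCCc1ccccc1)c1cccc(C2SCC(=O)N2c2cnccn2)c1` differs from compound 3 in one place: a group of 6 heavy atoms (4 carbon, 2 nitrogen; one six-membered aromatic ring with 2 hetero atoms) in place of a group of 10 heavy atoms (8 carbon, 2 fluorine; one six-membered aromatic ring of carbon only), on an amide-type nitrogen in a ring. Among the compounds with values here, two measured steps concern the same position, the group on an amide-type nitrogen in a ring. The first is an at least 9.0-fold higher number from compound 1 to compound 2 (0.95 log units; beyond the scatter), the second is an at least 34-fold lower number from compound 2 to compound 3 (1.53 log units; beyond the scatter); both show that changing this group moves the read-out well beyond the scatter, and that the compound bearing the difluoroethyl-substituted ring gave the lowest number. Within the data shown here, no measured compound carries pyrazin-2-yl at that position, so the direction of the new step is uncertain. Since the best group seen here is being exchanged for a smaller heteroaromatic ring, the number for compound 4 is expected to rise by a modest step, a 10-fold higher number from compound 3 to compound 4 (1.01 log units; beyond the scatter). The estimate for compound 4 is 300 nM, with a likely range from 60 nM to 2000 nM.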

Compound 4, half-maximal inhibitory concentration: > 1000 nM
Compound 4: a limit, no number; the forecaster's own chance of this, stated with the estimate: 30%; at least 3.3-fold (0.52 log units) between middle value and limit.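

In this assay, the exchange for pyrazin-2-yl on the amide-type nitrogen gives an at least 34-fold higher number from compound 3 to compound 4 (1.53 log units; beyond the scatter), and the comparison with the triazole-bearing compound gives an at least 9.0-fold higher number from compound 1 to compound 4 (0.95 log units; beyond the scatter). Compound 4 is recorded only as a limit of the assay, so these two steps give minimum sizes, and the step from compound 2 to compound 4 cannot be read. Until now only the 4-phenylphenyl group of compound 2 had reached this limit, but pyrazin-2-yl, with fewer heavy atoms than the group it replaces, reaches it as well, so groups both larger and smaller than the difluoroethyl-bearing ring can lose the low number at this position, and compound 2 and compound 4 now both sit at the limit: the limit of > 1000 nM in this assay, at which 2 of the 4 values shown sit.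

The compounds shown leave open how far beyond the limit compound 2 and compound 4 truly lie, so these two cannot be ranked against each other. They also leave open whether a plain phenyl ring, or a phenyl ring carrying an amine or a carboxylic acid in place of 1,1-difluoroethyl, would keep a low number in this assay.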